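Moving a bromine on the benzyl ether of a flavonol core

The compounds below may be only part of what the source reports. "The series", "measured", "known", "first", "only" and "open" are said of these compounds alone.

Compound 1 `O=c1c(OCc2cccc(Br)c2)c(-c2ccccc2)oc2cc(O)cc(O)c12` and compound 2 `O=c1c(OCc2cccc([N+](=O)[O-])c2)c(-c2ccccc2)oc2cc(O)cc(O)c12` share a core and differ only in the group on the benzyl ether. In an ADME assay on Huh-5-2 cells (Homo sapiens) for cytotoxicity, read by WST assay, with a stated time of 3 days (on this read-out higher numbers stand for lower toxicity in this test and lower numbers for higher toxicity in this test), compound 1 gives 15000 nM, and compound 2 gives 31000 nM. Among the compounds with values here, the single step between them, a 2.1-fold higher number from compound 1 to compound 2 (0.32 log units; beyond the scatter), is modest but beyond the scatter. Compound 2 therefore stands at the higher of the two numbers, with compound 1 at the lower one.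

Compound 3 `O=c1c(OCc2ccc(Br)cc2)c(-c2ccccc2)oc2cc(O)cc(O)c12` is the third member of the set. Relative to compound 2 the change is 4-bromophenyl in place of 3-nitrophenyl on a saturated chain carbon bound to an oxygen on an aromatic ring. Within the data shown here, only the step from compound 1 to compound 2 bears on this change, since it also exchanges nitro and bromo on that ring; compound 3 reverses that exchange, though its bromine does not sit on the same carbon as in compound 1. Because a 2.1-fold higher number from compound 1 to compound 2 (0.32 log units; beyond the scatter) was modest, the reversal is expected to give a modest lower number, a 1.8-fold lower number from compound 2 to compound 3 (0.26 log units; within the scatter). Compound 3 is thus estimated at 17000 nM, with a range from 8000 nM to 36000 nM.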

Compound 3, half-maximal cytotoxic concentration: 2000 nM
For compound 3 the middle estimate is 8.5-fold (0.93 log units) above the measured one; the whole stated range lies above it.
By their numbers in this assay, from the lowest: compound 3; then compound 1; then compound 2.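

Keeping the bromine and changing only its place on the benzyl ether, from 3-bromophenyl to 4-bromophenyl, moves the number in this assay far more than the nitro-for-bromo exchange did (a 7.5-fold lower number from compound 1 to compound 3 (0.88 log units; beyond the scatter)). Within the data shown here, this is the first sign in the set that where the group sits on this ring can matter as much as which group it is, and the lower number for compound 3 stands for higher toxicity in this test. The full change from 3-nitrophenyl to 4-bromophenyl gives a large step (a 16-fold lower number from compound 2 to compound 3 (1.19 log units; beyond the scatter)), and a comparison of the two steps suggests that much of it goes with the shift to the 4-bromophenyl arrangement, though no measurement here explains why.

A 4-nitrophenyl group on the same carbon would show whether the shift has a similar effect on a group other than bromine, and this cannot be told from the three compounds shown. Going by these compounds, it also remains open whether a 2-bromophenyl group, or an amine such as 4-aminophenyl, would follow the same trend.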